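This account rests on a few compounds, and the source may have more. Where it says the series, first, only, none or still open, it means among the compounds named here.

Compound 1 `Cc1ccc(-c2nn(-c3ccccc3)cc2-c2nc3ccccc3n2S(=O)(=O)c2ccc(F)cc2)cc1`: 128000 nM
Compound 2 `Cc1ccc(-c2nn(-c3ccccc3)cc2-c2nc3ccccc3n2S(=O)(=O)c2ccc(C(F)(F)F)cc2)cc1`: 182000 nM
Compound 3 `O=S(=O)(c1ccccc1)n1c(-c2cn(-c3ccccc3)nc2-c2ccc(F)cc2)nc2ccccc21`: 96300 nM

These three compounds were tested in an ADME assay on HEK-293T cells (Homo sapiens) for cytotoxicity, read by MTT assay, with a stated time of 24 h (a higher number here means that more compound is tolerated, a lower number that less compound is tolerated), and all three numbers lie close together. Compound 1 and compound 2 share one core and differ only by trifluoromethyl in place of fluoro on an aromatic carbon. This change gave a 1.4-fold higher number from compound 1 to compound 2 (0.15 log units; within the scatter), so the two compounds cannot be told apart by this measurement. Compound 3 has a different core; how its core differs from that of compound 1 is not broken down here, but in this assay compound 3 gives 96300 nM, a number within the scatter of both others.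

Compound 4 `O=S(=O)(c1ccccc1)n1c(-c2cn(-c3ccccc3)nc2-c2ccc(C(F)(F)F)cc2)nc2ccccc21` has not yet been measured. For the measured compounds named here, it is built from compound 3 by trifluoromethyl in place of fluoro on an aromatic carbon, the same change, at the same kind of place, as the one from compound 1 to compound 2. Since that earlier step stayed within the scatter, the step of a 1.4-fold higher number from compound 3 to compound 4 (0.15 log units; within the scatter) is expected to be of about the same small size, resting on a 1.4-fold higher number from compound 1 to compound 2 (0.15 log units; within the scatter). Compound 4 is therefore estimated at 135000 nM in this assay, with a likely range from 70000 nM to 260000 nM.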

Compound 4, half-maximal cytotoxic concentration: 128000 nM
For compound 4 the middle estimate is 1.1-fold (0.02 log units) above the measured one; the measured number falls inside the stated range.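

In this assay, the new step is a 1.3-fold higher number from compound 3 to compound 4 (0.12 log units; within the scatter), so this measurement cannot tell compound 3 and compound 4 apart. Placed next to the earlier result, trifluoromethyl in place of fluoro gives steps of about the same small size on the two cores: the same change on two cores in this assay, a 1.4-fold higher number (0.15 log units; within the scatter) from compound 1 to compound 2 and a 1.3-fold higher number (0.12 log units; within the scatter) from compound 3 to compound 4, 1.1-fold (0.03 log units) apart, within the scatter of two such steps. This shows that, on these two cores, the change left the number within the scatter and that the first step was a fair guide to the second, but two small steps do not show that the same would hold on a further core, and they explain nothing about why the steps are small.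

The compounds shown leave open whether a quite different group at this place, such as an amine, a carboxylic acid or a longer chain, would move the number beyond the scatter. They also leave open whether trifluoromethyl in place of fluoro would behave alike in any measurement other than this assay.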